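A Dimethylaminopropyl Chain on Two Closely Related Cores

This account rests on a few compounds, and the source may have more. Where it says the series, first, only, none or still open, it means among the compounds named here.

Compound 1 `Cc1cccc(C2=NCCNc3c2c(C)nn3C)c1` carries a hydrogen on the ring nitrogen; in a functional assay on the whole organism for positive allosteric modulation, with Rattus norvegicus as the target (on this read-out higher numbers stand for an effect only at larger amounts of compound and lower numbers for an effect already at smaller amounts), compound 1 gives 2.5 mg/kg. Compound 2 `Cc1cccc(C2=NCCN(CCCN(C)C)c3c2c(C)nn3C)c1` differs by 3-(dimethylamino)propyl in place of hydrogen on a nitrogen on an aromatic ring in a ring. For compound 2 this assay reports only a limit, > 10 mg/kg. That change gives an at least 4.0-fold higher number from compound 1 to compound 2 (0.60 log units; beyond the scatter), set by the limit of > 10 mg/kg in this assay, at which 1 of the 3 values shown sits. Compound 3 `Cc1ccc(C2=NCCNc3c2c(C)nn3C)cc1` has the same atoms as compound 1 joined differently; how the two cores differ is not broken down here. In this assay compound 3 gives 2.5 mg/kg. Compound 4 `Cc1ccc(C2=NCCN(CCCN(C)C)c3c2c(C)nn3C)cc1` differs from compound 3 by 3-(dimethylamino)propyl in place of hydrogen on a nitrogen on an aromatic ring in a ring, the same kind of change, the ring atom here bearing a 4-methylphenyl group rather than a 3-methylphenyl group. Compound 4 is expected to show a 6.0-fold higher number from compound 3 to compound 4 (0.78 log units; beyond the scatter), resting on an at least 4.0-fold higher number from compound 1 to compound 2 (0.60 log units; beyond the scatter). The expected value for compound 4 is 15 mg/kg, likely again only a limit.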

Compound 4, minimum effective dose: > 10 mg/kg
Compound 4 gave a limit, no number (the forecaster's own chance of this, stated with the estimate: 75%); the middle value is on the limit's open side.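

In this assay, 3-(dimethylamino)propyl in place of hydrogen on a nitrogen on an aromatic ring in a ring gives an at least 4.0-fold higher number from compound 3 to compound 4 (0.60 log units; beyond the scatter), so the change pushes the number the same way with a 4-methylphenyl group as with a 3-methylphenyl group. The step between compound 2 and compound 4 cannot be read, as both values are limits and not numbers. The direction therefore carries from one core to the other, but the true size of the step on each core stays unknown: the same change on two cores in this assay, an at least 4.0-fold higher number (0.60 log units; beyond the scatter) from compound 1 to compound 2 and an at least 4.0-fold higher number (0.60 log units; beyond the scatter) from compound 3 to compound 4; the limit leaves it open whether they differ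

The compounds shown leave open whether a smaller group on that nitrogen, such as methyl, would keep the effect at the smaller doses. As far as these compounds go, a shorter chain, such as 2-(dimethylamino)ethyl, stays equally open.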